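The compounds below may be only part of what the source reports. "The series", "measured", "known", "first", "only" and "open" are said of these compounds alone.

Compound 1 `Brc1cccc(Br)c1N(CC1CC1)C1=NCCN1` gives -1.12 in a physicochemical assay for lipophilicity; a lower number here means a more polar compound, a higher number a more lipophilic compound.
Compound 2 `CC(C)N(C1=NCCN1)c1c(Br)cccc1Br` gives -0.82 in this assay.
Compound 3 `CC(C)CN(C1=NCCN1)c1c(Br)cccc1Br` gives -0.64 in this assay.

Of these three numbers, compound 3 has the highest. The gap to compound 2 is small: a number 0.18 log units higher from compound 2 to compound 3 (within the scatter). The gap to compound 1 is larger: a number 0.48 log units higher from compound 1 to compound 3 (beyond the scatter).

Compound 4 `Brc1cccc(Br)c1N(CC1CCCC1)C1=NCCN1` differs from compound 3 in one place: cyclopentyl in place of isopropyl on a saturated chain carbon bound to a nitrogen on an aromatic ring. Two measured steps speak to this kind of change. One exchanged cyclopropyl for isopropyl on the saturated chain carbon, the step of a number 0.48 log units higher from compound 1 to compound 3 (beyond the scatter), which lay beyond the scatter. The other exchanged isopropyl for isobutyl on the nitrogen, the step of a number 0.18 log units higher from compound 2 to compound 3 (within the scatter), which lay within it. For the measured compounds named here, every step so far has moved the number upward as the group grew, with no compound going against this. A further upward step is therefore expected for compound 4, a number 0.49 log units higher from compound 3 to compound 4 (beyond the scatter), probably beyond the scatter but still modest. Compound 4 is thus estimated to give about -0.15 in this assay, within a range from -0.6 to 0.35.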

Compound 4, distribution coefficient: 0.32
Estimate against measurement, compound 4: 0.47 log units below; the range from low to high includes it.
By their numbers in this assay, from the lowest: compounds 1, 2 and 3 (each within the scatter of the next, the first and the last beyond it); then compound 4.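

Putting cyclopentyl in place of isopropyl on a saturated chain carbon bound to a nitrogen on an aromatic ring gives a number 0.96 log units higher from compound 3 to compound 4 (beyond the scatter) in this assay, so this position still responds strongly to a larger group. The same compound also separates clearly from the isopropyl analogue, with a number 1.14 log units higher from compound 2 to compound 4 (beyond the scatter) on going to cyclopentylmethyl on the nitrogen. Cyclopropyl and cyclopentyl are both carbon rings on the same chain carbon, yet they give a number 1.44 log units higher from compound 1 to compound 4 (beyond the scatter) as the widest gap in the set, so the presence of a ring alone does not fix the number here.

Nothing available explains why this step has the size it does. On these data alone, whether cyclohexyl would carry the rise further, and where a chain ending in an amine or a hydroxyl group would fall, stays open.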